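Phenyl in Place of Cyano: Expected Sigma-1 Binding

This account rests on a few compounds, and the source may have more. Where it says the series, first, only, none or still open, it means among the compounds named here.

compound 1, `COc1ccc(-c2cc3c(s2)C2(CCN(Cc4ccccc4)CC2)OC(OC)C3)cc1`: 56 nM
compound 2, `COC1Cc2cc(-c3ccc([N+](=O)[O-])cc3)sc2C2(CCN(Cc3ccccc3)CC2)O1`: 16 nM
compound 3, `COC1Cc2cc(-c3ccc(C#N)cc3)sc2C2(CCN(Cc3ccccc3)CC2)O1`: 20 nM

In an assay on membranes from brain for displacement of a labelled ligand from Sigma non-opioid intracellular receptor 1 (Cavia porcellus), read by scintillation counting, with a stated time of 120 min (on this read-out lower numbers stand for stronger inhibition and higher numbers for weaker inhibition), compound 3 gives 20 nM, the second highest of the three numbers. The step of a 1.3-fold higher number from compound 2 to compound 3 (0.10 log units; within the scatter) lies within the scatter, whereas a 2.8-fold lower number from compound 1 to compound 3 (0.45 log units; beyond the scatter) lies beyond it. Compound 4, `COC1Cc2cc(-c3ccc(-c4ccccc4)cc3)sc2C2(CCN(Cc3ccccc3)CC2)O1`, differs from compound 3 by phenyl in place of cyano on an aromatic carbon. Among the measured compounds shown here, no measured step introduces a phenyl; the two steps at this position, a 3.5-fold lower number from compound 1 to compound 2 (0.54 log units; beyond the scatter) and a 2.8-fold lower number from compound 1 to compound 3 (0.45 log units; beyond the scatter), were modest and show that the number at this site can move. The step of a 1.5-fold higher number from compound 3 to compound 4 (0.18 log units; within the scatter) is therefore expected to be small, with no clear direction beyond the scatter. Compound 4 is estimated at 30 nM, with a range from 8 nM to 110 nM.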

Compound 4, inhibition constant: 211 nM
Compound 4: middle estimate off by 7.0-fold (0.85 log units), on the low side; measured number above the stated range.
By their numbers in this assay, from the lowest: compounds 2 and 3 (each within the scatter of the next); then compound 1; then compound 4.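

Phenyl is the first group at this aromatic carbon to raise the number beyond the scatter: an 11-fold higher number from compound 3 to compound 4 (1.02 log units; beyond the scatter) and a 13-fold higher number from compound 2 to compound 4 (1.12 log units; beyond the scatter) are large steps, while a 3.8-fold higher number from compound 1 to compound 4 (0.58 log units; beyond the scatter) is modest. The site therefore does not accept every group alike, and the range spanned by methoxy, nitro and cyano did not reveal this limit. Nothing available accounts for the rise.

Going by these compounds, whether the loss follows from the added ring or from the removal of nitro or cyano remains open. So does how an amine, a carboxylic acid or a longer chain on this carbon would compare.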